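Aryl substituent variation on the triazole in a bicyclic lactam series

A few compounds are considered here, and "the series" means these few. Any claim that something is new, unique, unknown or untested is made for them only; others in the source may bear on it.

Measured compounds:
Compound 1 `CC1(C)[C@H]2CC[C@]1(C)N(Cc1cn(-c3cccc(F)c3)nn1)C(=O)C2`: 90 nM
Compound 2 `CC1(C)[C@H]2CC[C@]1(C)N(Cc1cn(-c3ccccc3C#N)nn1)C(=O)C2`: 140 nM

Within the data shown here, in a functional assay on LoVo cells (Homo sapiens) for inhibition, read by MTT assay, with a stated time of 24 h (a higher number here means a weaker inhibitor, a lower number a stronger inhibitor), compound 2 gives 140 nM, the highest of the two numbers so far; the nearest is compound 1, and the only measured step, a 1.6-fold higher number from compound 1 to compound 2 (0.19 log units; within the scatter), stays within the scatter, so the two compounds cannot be ordered.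

Compound 3 `Cc1ccccc1-n1cc(CN2C(=O)C[C@@H]3CC[C@@]2(C)C3(C)C)nn1` differs from compound 2 by methyl in place of cyano on an aromatic carbon. Among the measured compounds shown here, no measured step bears directly on this exchange: the one step known changed the whole aryl group rather than a single substituent on it, and that step was within the scatter. The series therefore gives no sign that the aryl substituent moves the number beyond the scatter, and a step of about a 1.1-fold lower number from compound 2 to compound 3 (0.03 log units; within the scatter) is expected, in no firm direction. Compound 3 is estimated at 130 nM, with a range of 55 nM to 320 nM.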

Compound 3, half-maximal inhibitory concentration: 80 nM
For compound 3 the middle estimate is 1.6-fold (0.21 log units) above the measured one, within the range that was stated.
By their numbers in this assay, from the lowest: compounds 3, 1 and 2 (each within the scatter of the next).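

In this assay, among these compounds, the change from 2-cyanophenyl to 2-methylphenyl is the first exchange of a single substituent on the aryl group, and it gives a 1.8-fold lower number from compound 2 to compound 3 (0.24 log units; within the scatter) so cyano and methyl cannot be told apart at this place. The step from a different aryl group, a 1.1-fold lower number from compound 1 to compound 3 (0.05 log units; within the scatter) is also small enough that 3-fluorophenyl and 2-methylphenyl cannot be ordered, and all three aryl groups shown now lie within the scatter of the next. No evidence on the cause of these numbers accompanies them.

Going by these compounds, whether any group on this aryl ring can move the number beyond the scatter remains open. An amine, a carboxylic acid or a longer alkyl chain at this place would test that, as would an unsubstituted phenyl as the reference.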